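A Chlorine Added Where Compound 3 Sits at the Limit

The source may hold more compounds than are shown below. What is called first, only, known or untested is meant among the compounds shown, and "the series" means these compounds.

Compound 1, `Nc1sc(-c2ccccc2)c(-c2cccc(C(F)(F)F)c2)c1C(=O)c1ccccc1`, is the anchor in a functional assay on CHO-K1 cells for agonist activity at adenosine receptor A1 (Homo sapiens), read by GTPgammaS binding (a lower number here means that less compound is needed, a higher number that more compound is needed for the effect), where compound 1 gives 2.3 uM. Compound 2, `Nc1sc(-c2ccc([N+](=O)[O-])cc2)c(-c2cccc(C(F)(F)F)c2)c1C(=O)c1ccccc1`, carries a nitro group in place of a hydrogen on an aromatic carbon; in this assay compound 2 gives only > 10 uM, which is a limit of the assay and not a number. Compound 3, `CCOC(=O)c1c(N)sc(-c2ccccc2)c1-c1cccc(C(F)(F)F)c1`, has ethoxy in place of phenyl on a carbonyl carbon; in this assay compound 3 likewise gives > 10 uM, again a limit rather than a number. Compound 3 therefore stands at the limit of > 10 uM in this assay, at which 2 of the 3 values shown sit, reached through an at least 4.3-fold higher number from compound 1 to compound 3 (0.63 log units; beyond the scatter).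

Compound 4, `CCOC(=O)c1c(N)sc(-c2ccc(Cl)cc2)c1-c1cccc(C(F)(F)F)c1`, differs from compound 3 by chloro in place of hydrogen on an aromatic carbon. The measured step that bears on this is an at least 4.3-fold higher number from compound 1 to compound 2 (0.63 log units; beyond the scatter), where a group entering on an aromatic carbon weakened the compound. Nothing in the data suggests that a chloro group would reverse this. Compound 4 is therefore expected to stay around the limit, the step that the limit leaves unreadable from compound 3 to compound 4 being estimated as none beyond the scatter. The expected value for compound 4 is 20 uM, within a range from 8 uM to 60 uM.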

Compound 4, concentration for half-maximal effect: 6.6 uM
Beside the measured number, compound 4's estimate is 3.0-fold (0.48 log units) above it, outside the stated range (below it).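

With chloro on this ring, in this assay compound 4 gives 6.6 uM, the first true number among the compounds shown that carry ethoxy on the carbonyl. Going from phenyl to 4-chlorophenyl gives an at least 1.5-fold lower number from compound 3 to compound 4 (0.18 log units; that floor lies within the scatter), so a real gain cannot be claimed from this floor alone, but the change clearly does not push the compound out of range. A new group at this place on the ring therefore need not cost activity as the nitro group did in an at least 4.3-fold higher number from compound 1 to compound 2 (0.63 log units; beyond the scatter), although that step involves another group on a different parent compound.

As far as these compounds go, the true size of the new step stays open because compound 3 has only a limit, one that is shared with compound 2: the limit of > 10 uM in this assay, at which 2 of the 4 values shown sit. Also open is whether a methoxy group or an amine in the same place would behave like chloro or like nitro.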